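The source may hold more compounds than are shown below. What is called first, only, known or untested is meant among the compounds shown, and "the series" means these compounds.

Measured compounds:
compound 1, `COC(=O)c1nc(C)n(-c2cccc(Br)c2)n1`: > 100000 nM
compound 2, `COC(=O)c1nc(C2CCCC2)n(-c2ccc(F)cc2)n1`: 10400 nM

In a functional assay on NPC-TW01 cells (Homo sapiens) for inhibition, read by MTT assay, with a stated time of 72 h (on this read-out higher numbers stand for weaker inhibition of growth and lower numbers for stronger inhibition of growth), compound 1 gives > 100000 nM, which is a limit rather than a number, as the limit of > 100000 nM in this assay, at which 1 of the 2 values shown sits, records. Compound 2 gives 10400 nM, the only number shown in this assay, so its standing rests on that single value. Compound 3, `COC(=O)c1nc(-c2ccccc2)n(-c2ccc(F)cc2)n1`, differs from compound 2 in phenyl in place of cyclopentyl on an aromatic carbon. Within the data shown here, no step between measured compounds is available, so no shift beyond the scatter is expected in either direction. Compound 3 is estimated at 9000 nM, within 2500 nM to 40000 nM, an expected step of a 1.2-fold lower number from compound 2 to compound 3 (0.06 log units; within the scatter).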

Compound 3, concentration for 50% growth inhibition: 15600 nM
Estimate against measurement, compound 3: 1.7-fold (0.24 log units) below; the range from low to high includes it.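

Phenyl in place of cyclopentyl on this aromatic carbon, between two ring nitrogen atoms, gives a 1.5-fold higher number from compound 2 to compound 3 (0.18 log units; within the scatter) in this assay. With the 4-fluorophenyl group and the methoxycarbonyl group held fixed, this read-out does not separate a five-membered non-aromatic ring from a six-membered aromatic ring at this position. No measured property bears on this result.

Open, from the compounds shown here alone, is whether an amine, a carboxylic acid or a longer chain on this carbon would give a step beyond the scatter. Also open, going by these compounds, is whether the same change reads alike with a ring other than 4-fluorophenyl on the ring nitrogen.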